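This account rests on a few compounds, and the source may have more. Where it says the series, first, only, none or still open, it means among the compounds named here.

Measured in a functional assay on MKN-45 cells (Homo sapiens) for cytotoxicity; on this read-out higher numbers stand for weaker inhibition and lower numbers for stronger inhibition:
- compound 1 `COc1ccc(S(=O)(=O)N2CCc3cccc(NC(=O)Oc4ccccc4)c32)cc1`: > 10000 nM (a limit of the assay, not a number)
- compound 2 `COc1ccc(S(=O)(=O)N2CCc3cccc(NC(C)=O)c32)cc1`: 61 nM

Among the measured compounds shown here, compound 2, at 61 nM, holds the only true number so far in this assay. For the measured compounds named here, the one other reading, that of compound 1, is a limit.

Compound 3 `COc1ccc(C(=O)Nc2cccc3c2N(S(=O)(=O)c2ccc(OC)cc2)CC3)cc1` is not yet measured. It differs from compound 2 on the carbonyl carbon whose other neighbours are the amide-type nitrogen: 4-methoxyphenyl in place of methyl on a carbonyl carbon, that is, 4-methoxyphenyl in place of methyl.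

Going by the values given here, one measured step bears on this change, and it is large: an at least 160-fold lower number from compound 1 to compound 2 (2.21 log units; beyond the scatter), with methyl in place of phenoxy on a carbonyl carbon. Read backwards, that step links a larger aromatic group on this carbon to a much weaker reading. It is a single pair, however, and phenoxy is not 4-methoxyphenyl, so its transfer to compound 3 is uncertain. A move towards weaker inhibition is expected, probably smaller than the measured step.

The expected change is a 3.3-fold higher number from compound 2 to compound 3 (0.52 log units; beyond the scatter). The estimate for compound 3 is 200 nM, with an expected range of 20 nM to 3000 nM.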

Compound 3, half-maximal inhibitory concentration: 1600 nM
Estimate against measurement, compound 3: 8.0-fold (0.90 log units) below, within the range that was stated.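

In this assay, a ring-bearing group on this carbonyl carbon now has a true number rather than a limit, and the change from the small group to the larger one gives a 26-fold higher number from compound 2 to compound 3 (1.42 log units; beyond the scatter). This shows that the acetyl group of compound 2 reads far stronger than the (4-methoxyphenyl)carbonyl group, without relying on the limit reading of compound 1. The two larger groups are also not interchangeable at this position, as the comparison gives an at least 6.2-fold lower number from compound 1 to compound 3 (0.79 log units; beyond the scatter), so an aromatic ring on this carbon lowers the reading without taking it out of the measurable range. The reading of compound 1 is a limit, so that last step fixes only a minimum size for the gap: the limit of > 10000 nM in this assay, at which 1 of the 3 values shown sits.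

With only methyl, phenoxy and 4-methoxyphenyl on this carbon, the compounds shown cannot separate the effect of the ring itself from that of its methoxy group. From the compounds shown here alone, whether a plain phenyl, a longer chain such as propyl, or an amine such as dimethylamino on this carbonyl carbon would read closer to compound 2 or to compound 3 remains open.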